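Compound 2 and a rearranged thiophene

The source may report more compounds than this note shows. Statements on the series, on what has been measured and on what is new or still open speak of the compounds shown alone.

Compound 1 `O=Cc1ccc(-c2cncc(Cl)c2N2CCC3(CCNC3=O)CC2)o1`: 5190 nM
Compound 2 `Cc1cc(-c2cncc(Cl)c2N2CCC3(CCNC3=O)CC2)sc1C=O`: 2530 nM

In a functional assay on MV4-11 cells (Homo sapiens) for inhibition, read by resazurin assay, with a stated time of 72 h (a lower number here means a stronger inhibitor of growth, a higher number a weaker inhibitor of growth), compound 2 has the lower of the two numbers, at 2530 nM. Compound 3 `CC(=O)c1sccc1-c1cncc(Cl)c1N1CCC2(CCNC2=O)CC1` differs from it as 2-acetylthiophen-3-yl in place of 5-formyl-4-methylthiophen-2-yl on an aromatic carbon, ortho to a large group. Among the measured compounds shown here, the sole measured step, a 2.1-fold lower number from compound 1 to compound 2 (0.31 log units; beyond the scatter), is modest and offers only a loose guide, as no measured compound carries the entering group. A step of similar size towards a higher number is expected, namely a 2.2-fold higher number from compound 2 to compound 3 (0.34 log units; beyond the scatter). For compound 3 the estimated value is 5500 nM, with an expected range of 1800 nM to 16000 nM.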

Compound 3, concentration for 50% growth inhibition: > 100000 nM
Compound 3: no number, only a limit; the forecaster's own chance of this, stated with the estimate: 10%; middle value at least 18-fold (1.25 log units) from the limit.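

The same atoms, joined differently, give an at least 39-fold higher number from compound 2 to compound 3 (1.59 log units; beyond the scatter), and the change from 5-formylfuran-2-yl gives an at least 19-fold higher number from compound 1 to compound 3 (1.28 log units; beyond the scatter). The arrangement of the thiophene and its carbonyl at this position therefore counts for far more than the earlier exchange of rings showed, which gave only a 2.1-fold lower number from compound 1 to compound 2 (0.31 log units; beyond the scatter). In this assay compound 3 carries a limit and not a number: the limit of > 100000 nM in this assay, at which 1 of the 3 values shown sits.

Compound 3 changes the ring attachment and the acetyl group together, and the compounds shown leave open which of the two matters. As far as these compounds go, how a 2-formylthiophen-3-yl group or a 2-carboxythiophen-3-yl group would behave at this position also remains open.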